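Indole to indane swap on the shared core, rat exposure

The source may hold more compounds than are shown below. What is called first, only, known or untested is meant among the compounds shown, and "the series" means these compounds.

Measured so far:
compound 1 `CCC(=O)Nc1cc(Nc2ncc(Br)c(Nc3ccc4cc[nH]c4c3)n2)c(OC)cc1N1CCN(C)CC1`, 348 ng.h/mL
compound 2 `C=CC(=O)Nc1cc(Nc2ncc(Br)c(Nc3ccc4ccn(C)c4c3)n2)c(OC)cc1N1CCN(C)CC1`, 515 ng.h/mL

In an ADME assay on the whole organism (Rattus norvegicus, strain Sprague-Dawley) for pharmacokinetics, read by LC-MS, with a stated time of 24 h, at a dose of 1 mg/kg by the intravenous route (on this read-out higher numbers stand for higher exposure at the dose given and lower numbers for lower exposure), compound 2 gives 515 ng.h/mL and compound 1 gives 348 ng.h/mL; the two numbers lie within the scatter of each other, so neither stands apart from the other. Within the data shown here, no step between measured compounds that differ in one place is available. Compound 3 `C=CC(=O)Nc1cc(Nc2ncc(Br)c(Nc3ccc4c(c3)CCC4)n2)c(OC)cc1N1CCN(C)CC1` differs from compound 2 by 2,3-dihydro-1H-inden-5-yl in place of 1-methyl-1H-indol-6-yl on a nitrogen on an aromatic ring. With nothing measured to lean on, the step is expected to be small, a 1.1-fold lower number from compound 2 to compound 3 (0.06 log units; within the scatter), in no sure direction beyond the scatter. Compound 3 is expected to give 450 ng.h/mL, with a range of 200 ng.h/mL to 1000 ng.h/mL.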

Compound 3, area under the concentration-time curve: 1050 ng.h/mL
Beside the measured number, compound 3's estimate is 2.3-fold (0.37 log units) below it; the measured number lies above the stated range.
By their numbers in this assay, from the lowest: compounds 1 and 2 (each within the scatter of the next); then compound 3.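

Among these compounds, with 2,3-dihydro-1H-inden-5-yl in place of 1-methyl-1H-indol-6-yl on a nitrogen on an aromatic ring, this assay shows a 2.0-fold higher number from compound 2 to compound 3 (0.31 log units; beyond the scatter) and gives the first single-place comparison. The group at this position can therefore shift exposure beyond the scatter, and a group of carbon only, without a ring nitrogen, is tolerated here. Nothing measured bears on the cause of this step. Open, on these data alone, is whether an amine or a carboxylic acid on the 2,3-dihydro-1H-inden-5-yl group would keep this exposure. Also open, as far as these compounds go, is whether the step carries over to other variants of the shared core.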